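Moving the methyl from the amine nitrogen onto the chain

The source may hold more compounds than are shown below. What is called first, only, known or untested is meant among the compounds shown, and "the series" means these compounds.

Compound 1, `CNCC[C@@H]1CCOC(c2ccccc2)(c2ccccc2)O1`: > 10000 nM, a limit of the assay.
Compound 2, `CC[C@@]1(c2ccccc2)OCC[C@@H](CCNC)O1`: 856 nM.
Compound 3, `CC[C@@]1(c2ccccc2)OCC[C@@H](CCNCc2ccccc2)O1`: 27 nM.

In an assay for displacement of a labelled ligand from Sigma non-opioid intracellular receptor 1 (Cavia porcellus), read by scintillation counting (a higher number here means a weaker inhibitor, a lower number a stronger inhibitor), compound 1 reaches only the limit of the assay, (the limit of > 10000 nM in this assay, at which 1 of the 3 values shown sits), so no number stands for it. Compound 4 is `NCCC[C@@H]1CCOC(c2ccccc2)(c2ccccc2)O1`, which differs from compound 1 by aminomethyl in place of methylamino on a saturated chain carbon, two bonds along the chain from a saturated ring carbon. For the measured compounds named here, the one step measured between two numbers, a 32-fold lower number from compound 2 to compound 3 (1.50 log units; beyond the scatter), came from enlarging the group on the amine nitrogen and lowered the number greatly. The change to compound 4 runs the other way, leaving the nitrogen with fewer attached carbons, so no gain is expected from it. Compound 4 is therefore expected to stay at the limit as well, estimated near 20000 nM with a range from 5000 nM to 80000 nM, an expected step that the limit leaves unreadable from compound 1 to compound 4.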

Compound 4, inhibition constant: 175 nM
Compound 4: middle estimate off by 110-fold (2.06 log units), on the high side, and the stated range ends above it.
By their numbers in this assay, from the lowest: compound 3; then compound 4; then compound 2. At a limit, above all of these: compound 1.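

In this assay, shifting one carbon from the amine nitrogen onto the chain, which turns 2-(methylamino)ethyl into 3-aminopropyl with the same atoms, gives an at least 57-fold lower number from compound 1 to compound 4 (1.75 log units; beyond the scatter). For the compounds shown here, at this position, then, how the same atoms are joined matters greatly, and adding carbon to the nitrogen is not the only change that lowers the number. The true size of this step cannot be read because compound 1 sits at a limit: the limit of > 10000 nM in this assay, at which 1 of the 4 values shown sits.

From the compounds shown here alone, it remains open whether a longer chain, such as 4-aminobutyl, keeps this gain. Going by these compounds, it is equally open whether a 3-hydroxypropyl chain, with a hydroxyl in place of the amine, keeps any of it.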